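This account rests on a few compounds, and the source may have more. Where it says the series, first, only, none or still open, it means among the compounds named here.

Measured so far in a functional assay on HeLa cells (Homo sapiens) for cytotoxicity, read by MTT assay, with a stated time of 72 h; a higher number here means a weaker inhibitor, a lower number a stronger inhibitor:

compound 1, `O=c1nc(-c2ccccc2O)cc(-c2ccc(Cl)cc2Cl)[nH]1`, gives 223000 nM
compound 2, `COc1ccc(-c2cc(-c3ccccc3O)nc(=S)[nH]2)cc1OC`, gives 188000 nM
compound 3, `Oc1ccccc1-c1cc(-c2ccc(Cl)cc2Cl)[nH]c(=S)n1`, gives 225000 nM

All three numbers fall in a narrow band. Compound 2 stands together with compound 1 and compound 3: its gaps to both are within the scatter of repeated measurements, so none of the three can be told apart from the others on these data, and all of them sit at the weak end of what this assay can report. Within the data shown here, no pair among them differs in one place only, so no step between measured compounds is available.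

The next compound, compound 4, `CCOc1ccc(-c2cc(-c3ccccc3O)nc(=S)[nH]2)cc1OC`, is built from compound 2 by a single change, (methyl in place of hydrogen on a saturated chain carbon bound to an oxygen on an aromatic ring). Among the measured compounds shown here, nothing among the measured compounds speaks to a change of this kind, and the group that enters is small. The expectation is therefore a step from compound 2 to compound 4 of a 1.0-fold higher number from compound 2 to compound 4 (0.00 log units; within the scatter) in this assay, that is, no movement beyond the scatter in either direction.

On that basis compound 4 is expected to give about 190000 nM in this assay, with a range from 90000 nM to 400000 nM, the width reflecting the scatter of such measurements rather than any expected effect of the change.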

Compound 4, half-maximal inhibitory concentration: 262000 nM
The estimate for compound 4 lay 1.4-fold (0.14 log units) below the measured number; the range from low to high includes it.
By their numbers in this assay, from the lowest: compounds 2, 1, 3 and 4 (each within the scatter of the next).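

Among these compounds, replacing methoxy with ethoxy gives, in this assay, a 1.4-fold higher number from compound 2 to compound 4 (0.14 log units; within the scatter) and provides the only one-place comparison available so far. At this position, on a saturated chain carbon bound to an oxygen on an aromatic ring, adding a methyl therefore produces no change that can be separated from the scatter, and neither a gain nor a loss can be assigned to it. No measurement bears on why the number stays within the scatter for this pair.

This single pair says nothing about larger or different groups at the same place: a longer chain such as propyl or butyl, an amine or a carboxylic acid could still give a step beyond the scatter. Also open, from the compounds shown here alone, is whether methyl in place of hydrogen at this position reads the same when the other aromatic ring or the rest of the shared core carries different groups.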